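Solubility of a Shared Core: Dropping One Methyl

The source may report more compounds than this note shows. Statements on the series, on what has been measured and on what is new or still open speak of the compounds shown alone.

Measured compounds:
compound 1, `Cc1cc(Nc2nccc(Nc3ccc4nc[nH]c4c3)n2)ccc1N1CCN(C)CC1`, 16000 nM in a physicochemical assay for solubility, read by HPLC, in phosphate buffer, at pH 7.4; a lower number here means a less soluble compound, a higher number a more soluble compound
compound 2, `Cc1cccc(Nc2ncc([N+](=O)[O-])c(Nc3ccc4nc[nH]c4c3)n2)c1`, 1000 nM in this assay

Of the compounds shown here, two built on one core have been measured. Compound 1 stands highest of the two numbers in this assay; its nearest neighbour is compound 2, whose number is lower by an amount well beyond the usual scatter of the measurement. The two differ in more than one place, so what they show is only their two values, not any single cause.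

Compound 3, `CN1CCN(c2ccc(Nc3nccc(Nc4ccc5nc[nH]c5c4)n3)cc2)CC1`, has not yet been measured. It differs from compound 1 in one place: hydrogen in place of methyl on an aromatic carbon. The methyl that leaves sits on an aromatic carbon of a six-membered aromatic ring of carbon only, ortho to a 4-methylpiperazin-1-yl group. Among the measured compounds shown here, nothing in the measured pair isolates this change, so the expectation rests on the single compound it starts from. A small step at most is expected for compound 3, a 1.1-fold lower number from compound 1 to compound 3 (0.03 log units; within the scatter), with no direction asserted beyond the scatter. Compound 3 is estimated at 15000 nM, within a range from 5000 nM to 45000 nM, pending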

Compound 3, solubility: 124000 nM
Beside the measured number, compound 3's estimate is 8.3-fold (0.92 log units) below it; measured number above the stated range.
By their numbers in this assay, from the lowest: compound 2; then compound 1; then compound 3.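

The change of hydrogen in place of methyl on an aromatic carbon, ortho to a 4-methylpiperazin-1-yl group, is the only step among these compounds that can be read on its own, and in this assay it amounts to a 7.8-fold higher number from compound 1 to compound 3 (0.89 log units; beyond the scatter). This carbon is therefore not a silent place for this read-out: the loss of a single heavy atom, with no hydrogen-bond donor, hydrogen-bond acceptor, ring or net charge leaving, is enough to move the number beyond the scatter. Nothing measured here explains the size or direction of this step, and no property of the methyl or its replacement is available as a measurement.

The compounds shown hold only methyl and hydrogen at this carbon, leaving open whether fluorine, chlorine or methoxy there would give a number nearer to compound 1 or to compound 3. As far as these compounds go, with one pair behind the step, it also stays open whether the same change would give a step of like size with a morpholine in place of the 4-methylpiperazin-1-yl group.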